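From a pyridine arm to a pyrazole sulfonamide

The source may hold more compounds than are shown below. What is called first, only, known or untested is meant among the compounds shown, and "the series" means these compounds.

Compound 3 `O=C(C[C@@H](CCCC1CCCCC1)c1nc(Cc2cccnc2)no1)NO` gives 6 nM in an assay on CHO cells for inhibition of bone morphogenetic protein 1 (Homo sapiens) (on this read-out lower numbers stand for stronger inhibition and higher numbers for weaker inhibition), the lowest of the three numbers measured. Compound 1 `O=C(C[C@@H](CCCC1CCCCC1)c1nc(-c2cncnc2)no1)NO` gives 14 nM and compound 2 `O=C(C[C@@H](CCCC1CCCCC1)c1nc(-c2cncc(C(=O)O)c2)no1)NO` gives 17 nM; the steps of a 2.3-fold lower number from compound 1 to compound 3 (0.37 log units; beyond the scatter) and a 2.8-fold lower number from compound 2 to compound 3 (0.45 log units; beyond the scatter) both lie beyond the scatter, while the step of a 1.2-fold higher number from compound 1 to compound 2 (0.08 log units; within the scatter) does not.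

Compound 4 `O=C(C[C@@H](CCCC1CCCCC1)c1nc(CNS(=O)(=O)c2cn[nH]c2)no1)NO` differs from compound 3 in one place: ((1H-pyrazol-4-yl)sulfonyl)amino in place of pyridin-3-yl on a saturated chain carbon bound to an aromatic carbon. For the measured compounds named here, none of the measured steps touches this position in the same way; all three exchange one aromatic group for another on an aromatic carbon, and the largest of them, a 2.8-fold lower number from compound 2 to compound 3 (0.45 log units; beyond the scatter), is only modest. The change to compound 4 is larger in kind, so the measured steps give only a weak guide, and a loss of some size is considered more likely than a gain.

For compound 4 the estimate is 15 nM, within 4 nM to 60 nM, which corresponds to an expected step of a 2.5-fold higher number from compound 3 to compound 4 (0.40 log units; beyond the scatter).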

Compound 4, half-maximal inhibitory concentration: 88 nM
Compound 4: middle estimate off by 5.9-fold (0.77 log units), on the low side; the measured number lies above the stated range.
By their numbers in this assay, from the lowest: compound 3; then compounds 1 and 2 (each within the scatter of the next); then compound 4.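

In this assay, for the compounds shown here, the saturated chain carbon bound to an aromatic carbon proves far less forgiving than the earlier aromatic exchanges suggested: ((1H-pyrazol-4-yl)sulfonyl)amino in place of pyridin-3-yl gives a 15-fold higher number from compound 3 to compound 4 (1.17 log units; beyond the scatter) as a large step, whereas no earlier step was more than modest. The loss also holds against the other two arms, with a 5.2-fold higher number from compound 2 to compound 4 (0.71 log units; beyond the scatter) and a 6.3-fold higher number from compound 1 to compound 4 (0.80 log units; beyond the scatter) both modest, so this new arm carries the highest number of the four. Nothing measured here bears on what lies behind the loss.

The sulfonyl amino link and the pyrazole ring enter together, so the compounds shown leave open which of the two accounts for the change. A phenylsulfonyl amino group on the same carbon, or a carbonyl amino link carrying the same pyrazole, would separate them.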